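A few compounds are considered here, and "the series" means these few. Any claim that something is new, unique, unknown or untested is made for them only; others in the source may bear on it.

Of the compounds shown here, three sharing one core have been tested in a functional assay for inhibition; on this read-out lower numbers stand for stronger inhibition and higher numbers for weaker inhibition. Compound 1 `CC(C)(C)c1cc(-c2cc(=O)c3ccc(OCC(=O)N4CCN(Cc5ccccc5)CC4)cc3o2)cc(C(C)(C)C)c1O` gives 3000 nM. Compound 2 `CC(C)(C)c1cc(-c2cc(=O)c3ccc(OCC(=O)O)cc3o2)cc(C(C)(C)C)c1O` has no single number, and its entries for compound 2 read 3000 nM; 100 nM (2 entries). Compound 3 `CC(C)(C)c1cc(-c2cc(=O)c3ccc(OCCCS(=O)(=O)O)cc3o2)cc(C(C)(C)C)c1O` gives 500 nM, the lower of the two single numbers, and the gap up to compound 1 lies beyond the scatter.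

Compound 4 `CCCCCCOc1ccc2c(=O)cc(-c3cc(C(C)(C)C)c(O)c(C(C)(C)C)c3)oc2c1` has not yet been measured. It keeps the core of compound 3 and differs in the chain: propyl in place of sulfo on a saturated chain carbon, three bonds along the chain from an oxygen on an aromatic ring. Taken as a whole chain, 3-sulfopropyl becomes hexyl.

Going by the values given here, no two measured compounds differ in just one place, so the size of this change can only be judged loosely. Compound 1, which also carries no sulfo group, stands at 3000 nM, and this tilts the expectation towards weaker inhibition. A moderate step in that direction is expected, a 3.0-fold higher number from compound 3 to compound 4 (0.48 log units; beyond the scatter). Compound 2 lacks the sulfo group as well, and the range stays wide because of the several entries of compound 2 in this assay, 3000 nM; 100 nM (2 entries). For compound 4 the estimated value is 1500 nM, with an expected range of 300 nM to 6000 nM.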

Compound 4, half-maximal inhibitory concentration: 5000 nM
Compound 4: middle estimate off by 3.3-fold (0.52 log units), on the low side; the range from low to high includes it.
By their numbers in this assay, from the lowest: compound 3; then compounds 1 and 4 (each within the scatter of the next).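

Going by these compounds alone, replacing sulfo with propyl on a saturated chain carbon, three bonds along the chain from an oxygen on an aromatic ring, gives in this assay the first direct comparison: a 10-fold higher number from compound 3 to compound 4 (1.00 log units; beyond the scatter). The earlier compounds shown here differed in more than one place and could only hint at the role of the sulfo group, whereas this pair shows that the end of this chain affects the read-out and that, on the shared core, 3-sulfopropyl gives the stronger inhibition of the two chains. Inhibition is not lost altogether without the sulfo group, as compound 4 still gives a number of 5000 nM, but this single exchange alters the size and the atoms of the group at once, so it cannot show which of these differences accounts for the step.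

Going by these compounds, whether a carboxylic acid or an amine at the end of the chain, or a chain longer than hexyl, would give a lower or a higher number remains open. The standing of compound 2 is also unsettled because its entries disagree: the several entries of compound 2 in this assay, 3000 nM; 100 nM (2 entries)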